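Turning one ring stereocentre, and a chain stereocentre too

This account rests on a few compounds, and the source may have more. Where it says the series, first, only, none or still open, it means among the compounds named here.

Compound 1 `C[C@H](CO)N1C[C@H](C)[C@@H](CN(C)Cc2ccc(Oc3ccccc3)cc2)Oc2c(NC(=O)c3ccncc3)cccc2C1=O`: 70%
Compound 2 `C[C@H](CO)N1C[C@H](C)[C@H](CN(C)Cc2ccc(Oc3ccccc3)cc2)Oc2c(NC(=O)c3ccncc3)cccc2C1=O`: < 1%

Among the measured compounds shown here, in an ADME assay on microsomes (Mus musculus) for metabolic stability, with a stated time of 1 h, tested at 1 uM (a higher number here means that more of the compound is left, a lower number that less of the compound is left), compound 1 gives 70%, the only true number so far. Compound 2 reads < 1%, which is a limit of the assay and not a number. The measured change is a number at least 69 percentage points lower from compound 1 to compound 2 (beyond the scatter), and it comes with the fact that compounds 1 and 2 differ only in the configuration as drawn.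

Compound 3 `C[C@H]1CN([C@@H](C)CO)C(=O)c2cccc(NC(=O)c3ccncc3)c2O[C@H]1CN(C)Cc1ccc(Oc2ccccc2)cc1` has not been measured. Its structure compared with compound 1 is this: the two compounds have the same atoms and bonds and differ only in configuration as drawn: 2 of 3 stereo elements differ; a stereocentre at a saturated chain carbon is drawn R in compound 1 and S in compound 3; a stereocentre at a saturated ring carbon is drawn S in compound 1 and R in compound 3. The ring carbon changes just as it does in a number at least 69 percentage points lower from compound 1 to compound 2 (beyond the scatter), so that step is the guide here. For the measured compounds named here, no measured step covers the chain carbon, which keeps the range wide. A large fall is expected, an estimated a number 62 percentage points lower from compound 1 to compound 3 (beyond the scatter). The expected value for compound 3 is 8%, within an estimated range of 1% to 40%.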

Compound 3, percent of the compound remaining: < 1%
Compound 3: a limit, no number (the forecaster's own chance of this, stated with the estimate: 30%); middle value at least 7 percentage points from the limit.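

In this assay, turning the chain stereocentre together with the ring stereocentre gives a number at least 69 percentage points lower from compound 1 to compound 3 (beyond the scatter), so changing the chain carbon as well does not bring back the stability of compound 1. Compound 3 reads < 1%, which is a limit of the assay and not a number. The step from compound 2 to compound 3, where only the chain carbon changes, cannot be read, and any effect of that carbon stays hidden at this floor: the limit of < 1% in this assay, at which 2 of the 3 values shown sit.

The compounds shown leave open what the chain stereocentre does on its own while the ring carbon stays as drawn in compound 1. Also open, from the compounds shown here alone, is whether a longer chain, or an amine in place of the alcohol on that chain, would read differently.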